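This account rests on a few compounds, and the source may have more. Where it says the series, first, only, none or still open, it means among the compounds named here.

Measured so far:
- compound 1 `O=C(CCc1cccc2c1B(O)OC2)Nc1ccccc1`: 230 nM
- compound 2 `O=C(CCc1cccc2c1B(O)OC2)Nc1cccc(-c2ccccc2)c1`: 220 nM

Both values come from a functional assay on MDA-MB-231 cells (Homo sapiens) for antiproliferative activity, read by MTT assay, with a stated time of 72 h; a lower number here means a stronger inhibitor, a higher number a weaker inhibitor. With only these two compounds measured, compound 2 lies within the scatter of compound 1, so the pair cannot be ranked.

Compound 3 `O=C(CCc1cccc2c1B(O)OC2)Nc1cccc(-c2cccc(OC(F)(F)F)c2)c1` differs from compound 2 by trifluoromethoxy in place of hydrogen on an aromatic carbon of a six-membered aromatic ring of carbon only, meta to a large group.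

Among the compounds with values here, one measured step bears on this change: a 1.0-fold lower number from compound 1 to compound 2 (0.02 log units; within the scatter), with phenyl in place of hydrogen on an aromatic carbon. Within the data shown here, that single step is thin evidence, and no measured compound carries trifluoromethoxy, so the range stays wide. In this assay, no step beyond the scatter is expected, in either direction. The estimated step is no change at the digits printed from compound 2 to compound 3 (within the scatter). For compound 3 the expected value is 220 nM, with an estimated range of 90 nM to 520 nM.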

Compound 3, half-maximal inhibitory concentration: 460 nM
The estimate for compound 3 lay 2.1-fold (0.32 log units) below the measured number, and the stated range covers the measured number.
By their numbers in this assay, from the lowest: compounds 2, 1 and 3 (each within the scatter of the next, the first and the last beyond it).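

In this assay, within the data shown here, the ring brought in by the phenyl group is not indifferent to further substitution: trifluoromethoxy on an aromatic carbon of that ring, meta to a large group, gives a 2.1-fold higher number from compound 2 to compound 3 (0.32 log units; beyond the scatter) and so the first step beyond the scatter. The step is modest, but it points toward weaker inhibition, whereas the phenyl step itself, a 1.0-fold lower number from compound 1 to compound 2 (0.02 log units; within the scatter), showed no change that could be read. No measurement at hand accounts for this step.

A single substituent at a single place cannot separate an effect of trifluoromethoxy from an effect of any group on this carbon. Going by these compounds, whether fluorine, methoxy, an amine or a carboxylic acid on the same carbon would keep the number of the unsubstituted ring stays open, as does the outcome for trifluoromethoxy on other carbons of the ring.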